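Changing the Group on the Carbonyl Carbon

The source may hold more compounds than are shown below. What is called first, only, known or untested is meant among the compounds shown, and "the series" means these compounds.

Three compounds share one core and differ only in the group attached to a carbonyl carbon. In an assay on membranes from CHO cells for displacement of a labelled ligand from adenosine receptor A1 (Homo sapiens), read by scintillation counting, with a stated time of 60 min, tested at 1 uM (a higher number here means more inhibition at the concentration tested (going by the name of the read-out), a lower number less inhibition), compound 1 `CCCC(=O)C1=C(C)NC(=O)NC1c1cccs1` gives 2%, compound 2 `CC1=C(C(=O)NC(C)C)C(c2cccs2)NC(=O)N1` gives 2%, and compound 3 `CC1=C(C(=O)SC(C)C)C(c2cccs2)NC(=O)N1` gives 1%. Compound 3 has the lowest of these three numbers, but the gaps are small: a number 1 percentage points lower from compound 1 to compound 3 (within the scatter) and a number 1 percentage points lower from compound 2 to compound 3 (within the scatter). Compound 4 `CC1=C(C(=O)OC2CCCCC2)C(c2cccs2)NC(=O)N1` differs from compound 3 in one place: cyclohexyloxy in place of isopropylsulfanyl on a carbonyl carbon. Every measured step at this position, including no change at the digits printed from compound 1 to compound 2 (within the scatter), stayed within the scatter, so no change beyond the scatter is expected in this assay, in either direction. Compound 4 is therefore estimated at 3%, between -6% and 14%, which means an expected step of a number 2 percentage points higher from compound 3 to compound 4 (within the scatter).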

Compound 4, a percentage reported as inhibition, at one concentration (the size of the read-out at that concentration, not a potency): 7%
Estimate against measurement, compound 4: 4 percentage points below; low and high end bracket the measured number.
By their numbers in this assay, from the lowest: compounds 3, 1, 2 and 4 (each within the scatter of the next).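

Unlike the other three groups, cyclohexyloxy brings a ring to the carbonyl carbon, yet in this assay the steps stay small: a number 6 percentage points higher from compound 3 to compound 4 (within the scatter) along with a number 5 percentage points higher from compound 2 to compound 4 (within the scatter) and a number 5 percentage points higher from compound 1 to compound 4 (within the scatter). So even this six-membered ring of carbon only does not set compound 4 clear of the other three compounds. Nothing at hand bears on this result. Going by these compounds, whether a benzyloxy group or a free carboxylic acid at this carbonyl carbon would give a step beyond the scatter remains open.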